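A Halogen Swap Tested on a Second Core

This account rests on a few compounds, and the source may have more. Where it says the series, first, only, none or still open, it means among the compounds named here.

Of the compounds shown here, three have been measured in a functional assay on A549 cells (Homo sapiens) for inhibition, read by MTT assay, with a stated time of 48 h; a lower number here means a stronger inhibitor, a higher number a weaker inhibitor. Compound 1, `COc1ccc(C(=O)CSc2nc3c([nH]2)c(=O)n(C)c(=O)n3C)cc1`, gives 7900 nM in this assay. Compound 2, `Cn1c(=O)c2[nH]c(SCC(=O)c3ccc(Cl)cc3)nc2n(C)c1=O`, gives 8400 nM in this assay. The two differ by chloro in place of methoxy on an aromatic carbon, and the step of a 1.1-fold higher number from compound 1 to compound 2 (0.03 log units; within the scatter) is recorded as within the scatter. Compound 3, `COc1ccc(/C(CSc2nc3[nH]c(=O)n(C)c(=O)c3[nH]2)=N\O)cc1`, gives 1500 nM in this assay, the lowest of the three numbers; its nearest neighbour is compound 1, whose number is higher by a margin beyond the scatter, and compound 2 lies a little further off. How the core of compound 3 differs from the core of compound 1 is not broken down here.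

Compound 4, `Cn1c(=O)[nH]c2nc(SC/C(=N/O)c3ccc(Cl)cc3)[nH]c2c1=O`, has not yet been measured in this assay. It differs from compound 3 by chloro in place of methoxy on an aromatic carbon, the same change that separates compound 2 from compound 1, made at the same kind of place on the same ring. Because that earlier step a 1.1-fold higher number from compound 1 to compound 2 (0.03 log units; within the scatter) stayed within the scatter, compound 4 is expected to sit close to compound 3, with an estimated step of a 1.1-fold higher number from compound 3 to compound 4 (0.05 log units; within the scatter) in this assay. On that basis, compound 4 is estimated to give about 1700 nM in this assay, likely between 700 nM and 4000 nM, with the measurement itself still to come.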

Compound 4, half-maximal inhibitory concentration: 1890 nM
Compound 4: the middle estimate sits 1.1-fold (0.05 log units) below what was measured, and the stated range covers the measured number.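

In this assay, replacing the 4-methoxyphenyl group with 4-chlorophenyl on the core shared by the later pair gives a 1.3-fold higher number from compound 3 to compound 4 (0.10 log units; within the scatter), so the two values of that pair cannot be told apart, just as those of the earlier pair could not. Set side by side, the two steps agree: the same change on two cores in this assay, a 1.1-fold higher number (0.03 log units; within the scatter) from compound 1 to compound 2 and a 1.3-fold higher number (0.10 log units; within the scatter) from compound 3 to compound 4, 1.2-fold (0.07 log units) apart, within the scatter of two such steps Within this series, then, the swap of methoxy for chloro carried from one core to the other without a readable effect on either, although this rests on just two pairs in a single assay, and it does not show that the two groups are interchangeable on any other core or in any other kind of measurement, nor can steps this small reveal a slight real difference or explain why the number holds.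

The compounds shown carry only methoxy or chloro at this place on the aromatic ring, so it remains open whether an amine, a carboxylic acid or a fluoro group there would leave the number equally undisturbed. On these data alone, it is also open whether a longer chain carrying the same aromatic ring would behave the same way on either core.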